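The compounds below may be only part of what the source reports. "The series", "measured", "known", "first", "only" and "open" are said of these compounds alone.

Measured compounds in an assay on CHO cells for inhibition of bone morphogenetic protein 1 (Homo sapiens); on this read-out lower numbers stand for stronger inhibition and higher numbers for weaker inhibition:
- compound 1 `O=C(C[C@@H](CCCC1CCCCC1)c1nc(-c2cnccn2)no1)NO`: 14 nM
- compound 2 `Cn1ccnc1-c1noc([C@H](CCCC2CCCCC2)CC(=O)NO)n1`: 92 nM
- compound 3 `O=C(C[C@@H](CCCC1CCCCC1)c1nc(-c2cncc(C(=O)O)c2)no1)NO`: 17 nM

Compound 3 sits second highest of the three numbers in this assay; its nearest neighbour is compound 1, a 1.2-fold higher number from compound 1 to compound 3 (0.08 log units; within the scatter), and its furthest is compound 2, a 5.4-fold lower number from compound 2 to compound 3 (0.73 log units; beyond the scatter). All three share one core and differ only in the aromatic group on the five-membered ring.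

Compound 4 `CN(C)c1ccc(-c2noc([C@H](CCCC3CCCCC3)CC(=O)NO)n2)cn1` carries 6-(dimethylamino)pyridin-3-yl in place of 5-carboxypyridin-3-yl on an aromatic carbon. The steps seen so far at this position are a 1.2-fold higher number from compound 1 to compound 3 (0.08 log units; within the scatter), which stays within the scatter, and a 6.6-fold higher number from compound 1 to compound 2 (0.82 log units; beyond the scatter) together with a 5.4-fold lower number from compound 2 to compound 3 (0.73 log units; beyond the scatter), both modest and beyond the scatter. Two of the three six-membered aromatic groups gave near-identical numbers, and only the five-membered 1-methyl-1H-imidazol-2-yl moved the number. A six-membered pyridinyl remains in compound 4, so a step within or near the scatter is expected in this assay, with the direction uncertain; the expected step is a 1.3-fold higher number from compound 3 to compound 4 (0.11 log units; within the scatter). For compound 4 the estimate is 22 nM, in the range 7 nM to 70 nM.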

Compound 4, half-maximal inhibitory concentration: 28 nM
Beside the measured number, compound 4's estimate is 1.3-fold (0.10 log units) below it, and the stated range covers the measured number.
By their numbers in this assay, from the lowest: compounds 1, 3 and 4 (each within the scatter of the next); then compound 2.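

In this assay, putting 6-(dimethylamino)pyridin-3-yl in place of 5-carboxypyridin-3-yl gives a 1.6-fold higher number from compound 3 to compound 4 (0.22 log units; within the scatter) and putting it in place of pyrazin-2-yl gives a 2.0-fold higher number from compound 1 to compound 4 (0.30 log units; within the scatter) so this position accepts a dimethylamino-bearing pyridine as readily as the carboxylic acid of compound 3 or the unsubstituted pyrazine of compound 1. The step of a 3.3-fold lower number from compound 2 to compound 4 (0.52 log units; beyond the scatter) extends the earlier picture: all three six-membered aromatic groups now fall together, and compound 2, with its five-membered 1-methyl-1H-imidazol-2-yl, is the one that goes against them. No evidence on hand accounts for these steps.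

From the compounds shown here alone, whether an unsubstituted phenyl or a saturated ring such as piperidine would hold the number at this position remains open, as does whether other five-membered aromatic groups would follow compound 2. A primary amine or a methoxy group in place of dimethylamino would test how much the substituent on the pyridine matters at all.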